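This account rests on a few compounds, and the source may have more. Where it says the series, first, only, none or still open, it means among the compounds named here.

Measured so far in an ADME assay on Vero cells (Chlorocebus sabaeus) for cytotoxicity, read by CellTiter-Glo, with a stated time of 72 h; on this read-out higher numbers stand for lower toxicity in this test and lower numbers for higher toxicity in this test:
- compound 1 `[O-][n+]1nc(NC2CC2)[n+]([O-])c2ccccc21`: 21 ug/mL
- compound 2 `[O-][n+]1nc(NC2CCCC2)[n+]([O-])c2ccccc21`: 10 ug/mL
- compound 3 `[O-][n+]1nc(NC2CCCC2)[n+]([O-])c2ccc(Br)cc21`: 18 ug/mL

Compound 2, at 10 ug/mL, sits at the low end of these three numbers, within the scatter of compound 3 at 18 ug/mL. Among the compounds with values here, only one measured step lies beyond the scatter: a 2.1-fold lower number from compound 1 to compound 2 (0.32 log units; beyond the scatter). That change, cyclopentyl in place of cyclopropyl on a nitrogen on an aromatic ring, is at a different place from the one considered here and bears on it little.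

The next compound to be measured is compound 4 `Cc1cccc2c1[n+]([O-])c(NC1CCCC1)n[n+]2[O-]`. Its difference from compound 2 is methyl in place of hydrogen on an aromatic carbon. The closest measured precedent is a 1.8-fold higher number from compound 2 to compound 3 (0.26 log units; within the scatter), with bromo in place of hydrogen on an aromatic carbon. This is a single example with a different group, so it gives only weak guidance on direction. No step beyond the scatter is expected in this assay, and no direction is firmly expected.

The expected step is a 1.3-fold higher number from compound 2 to compound 4 (0.11 log units; within the scatter). For compound 4 the estimated value is 13 ug/mL, with an expected range of 7 ug/mL to 24 ug/mL.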

Compound 4, half-maximal cytotoxic concentration: 3.7 ug/mL
Compound 4: the middle estimate sits 3.5-fold (0.55 log units) above what was measured; the measured number lies below the stated range.
By their numbers in this assay, from the lowest: compound 4; then compounds 2, 3 and 1 (each within the scatter of the next, the first and the last beyond it).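

In this assay, methyl on an aromatic carbon, ortho to a fused ring and meta to a fused ring, gives a 2.7-fold lower number from compound 2 to compound 4 (0.43 log units; beyond the scatter) and so moves the number beyond the scatter, toward higher toxicity in this test. The only earlier substitution on this aromatic ring, with bromo on a different carbon, gives a 1.8-fold higher number from compound 2 to compound 3 (0.26 log units; within the scatter) and stays within the scatter, so the ring can no longer be treated as a place where substitution leaves this read-out unchanged. Group and ring carbon both differ between these two steps, so the series cannot yet say which of them sets the size of the step, and nothing measured on these compounds accounts for it.

Still open, going by these compounds, is whether the lower number belongs to methyl or to this ring carbon: an amine, a methoxy group or a fluoro group at the same place, or methyl on another ring carbon, would begin to separate the two. Also open, on these data alone, is whether the step carries over when the cyclopentyl on the nitrogen is replaced by the cyclopropyl of compound 1 or by a longer chain.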